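The source may report more compounds than this note shows. Statements on the series, on what has been measured and on what is new or still open speak of the compounds shown alone.

Three measured compounds frame this step. Compound 1 `CCC(=O)[C@H]1O[C@@H](n2cnc3c(N)nc(C#Cc4ccccc4)nc32)[C@H](O)[C@@H]1O` gives 3920 nM in an assay on CHO cells for displacement of a labelled ligand from adenosine receptor A1 (Homo sapiens); a higher number here means a weaker inhibitor, a lower number a stronger inhibitor. Compound 2 `CONc1nc(C#CCCCC#N)nc2c1ncn2[C@@H]1O[C@H](CO)[C@@H](O)[C@H]1O` gives 282 nM in this assay, and compound 3 `CONc1nc(C#CC2CCCCC2O)nc2c1ncn2[C@@H]1O[C@H](CO)[C@@H](O)[C@H]1O` gives 34 nM, the lowest of the three numbers; its gap to compound 2 is beyond the scatter, and its wider gap to compound 1 is as well. Among the compounds with values here, the one measured step that changes a single place, an 8.3-fold lower number from compound 2 to compound 3 (0.92 log units; beyond the scatter), came with 2-hydroxycyclohexyl in place of 3-cyanopropyl on a triple-bonded carbon. Compound 4 `CONc1nc(C#Cc2cccnc2)nc2c1ncn2[C@@H]1O[C@H](CO)[C@@H](O)[C@H]1O` differs from compound 3 by pyridin-3-yl in place of 2-hydroxycyclohexyl on a triple-bonded carbon. Within the data shown here, no measured step exchanges a six-membered non-aromatic ring for an aromatic ring on this core, so that earlier step bears on the present one only loosely. Compound 4 is expected to sit near compound 3, at an estimated 80 nM in this assay, with a range from 20 nM to 300 nM. The expected step is a 2.4-fold higher number from compound 3 to compound 4 (0.37 log units; beyond the scatter), a modestly higher number that may not clear the scatter.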

Compound 4, inhibition constant: 255 nM
Estimate against measurement, compound 4: 3.2-fold (0.50 log units) below, within the range that was stated.
By their numbers in this assay, from the lowest: compound 3; then compounds 4 and 2 (each within the scatter of the next); then compound 1.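

In this assay, the exchange on the triple-bonded carbon brought a 7.5-fold higher number from compound 3 to compound 4 (0.88 log units; beyond the scatter), so at this position one six-membered ring did not stand in for another. Set against the open chain, pyridin-3-yl gave a 1.1-fold lower number from compound 2 to compound 4 (0.04 log units; within the scatter), which leaves 2-hydroxycyclohexyl as the only one of the three groups set apart by its number. Nothing at hand explains this difference. The compounds shown leave open whether plain cyclohexyl, without the hydroxyl, would stand with compound 3 or with compound 4, and whether phenyl or pyridin-4-yl on the shared core of compound 4 would differ from pyridin-3-yl.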